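The source may hold more compounds than are shown below. What is called first, only, known or untested is meant among the compounds shown, and "the series" means these compounds.

Compound 1 `O=C(Nc1cccc(-n2cc(-c3ccncc3)c(-c3cc(O)cc(Cl)c3)n2)c1)Nc1ccc(Cl)c(C(F)(F)F)c1` and compound 2 `COc1cc(Cl)cc(-c2nn(-c3cccc(NC(=O)Nc4ccc(Cl)c(C(F)(F)F)c4)c3)cc2-c2ccncc2)c1` share one core and differ only in a methyl in place of hydrogen on an oxygen on an aromatic ring. In a functional assay on SR cells (Homo sapiens) for inhibition, read by sulforhodamine B assay, with a stated time of 48 h, tested at 0.01 uM (on this read-out lower numbers stand for a stronger effect and higher numbers for a weaker effect at the one concentration tested), compound 1 gives 105%, and compound 2 gives 95%, so the two sit within the usual scatter of each other (a number 10 percentage points lower from compound 1 to compound 2 (within the scatter)). Compound 3 `COc1cc(Cl)cc(-c2nn(-c3cccc(NC(=O)Nc4cccc(C(F)(F)F)c4)c3)cc2-c2ccncc2)c1` differs from compound 2 by hydrogen in place of chloro on an aromatic carbon. For the measured compounds named here, no measured step touches this part of the molecule; the only step seen is small. Compound 3 is therefore expected to show a number 3 percentage points higher from compound 2 to compound 3 (within the scatter), an estimate of 98% within 85% to 110%.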

Compound 3, a percentage reported as activity, at one concentration (the size of the read-out at that concentration, not a potency): 89%
Compound 3: the middle estimate sits 9 percentage points above what was measured; measured number inside the range.
By their numbers in this assay, from the lowest: compounds 3, 2 and 1 (each within the scatter of the next, the first and the last beyond it).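

With hydrogen in place of chloro on the 4-chloro-3-(trifluoromethyl)phenyl ring, a number 6 percentage points lower from compound 2 to compound 3 (within the scatter) appears in this assay at the one concentration tested. For the compounds shown here, the earlier step concerned only the oxygen on the other aromatic ring, so this is the first sign that this position can also lose its chloro group without a change beyond the scatter. No available evidence explains this result.

As far as these compounds go, whether an amine or a carboxylic acid at this position would shift the read-out remains open. So does the effect of replacing the trifluoromethyl group.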